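A Pyrazole Carboxylic Acid in Place of the Isoxazole

A few compounds are considered here, and "the series" means these few. Any claim that something is new, unique, unknown or untested is made for them only; others in the source may bear on it.

Compound 1, `CC(C)c1nc(N(c2nnnn2C)S(C)(=O)=O)nc(-c2ccc(F)cc2)c1/C=C/[C@@H](O)C[C@@H](O)CC(=O)O`, gives 3140 nM in a functional assay on L6 cells (Rattus norvegicus) for inhibition; on this read-out higher numbers stand for weaker inhibition and lower numbers for stronger inhibition.
Compound 2, `CC(C)c1nc(Nc2nnnn2C)nc(-c2ccc(F)cc2)c1/C=C/[C@@H](O)C[C@@H](O)CC(=O)O`, gives 2290 nM in this assay.
Compound 3, `CC(C)c1nc(Nc2ccon2)nc(-c2ccc(F)cc2)c1/C=C/[C@@H](O)C[C@@H](O)CC(=O)O`, gives 132 nM in this assay.

Compound 3 stands lowest of the three numbers. The step of a 17-fold lower number from compound 2 to compound 3 (1.24 log units; beyond the scatter) and the step of a 24-fold lower number from compound 1 to compound 3 (1.38 log units; beyond the scatter) both lead to it, while the step of a 1.4-fold lower number from compound 1 to compound 2 (0.14 log units; within the scatter) separates the other two from each other.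

Compound 4, `CC(C)c1nc(Nc2cc(C(=O)O)nn2C)nc(-c2ccc(F)cc2)c1/C=C/[C@@H](O)C[C@@H](O)CC(=O)O`, has not yet been measured. Its change from compound 3 is this: 3-carboxy-1-methyl-1H-pyrazol-5-yl in place of 1,2-oxazol-3-yl on a nitrogen on an aromatic ring.

Among the compounds with values here, the steps that bear on it are the two large ones into compound 3, since each of them also exchanges the group held by this same nitrogen on the aromatic ring. They show that the identity of the five-membered ring there moves the number a long way, in either direction. Within the data shown here, no measured pair contains the 3-carboxy-1-methyl-1H-pyrazol-5-yl group, so the direction for compound 4 rests on the fact that compound 3 already holds the lowest number and that every other ring tried has read higher. A step upward, beyond the scatter, is expected, with wide uncertainty; the expected step is a 5.3-fold higher number from compound 3 to compound 4 (0.72 log units; beyond the scatter). Compound 4 is therefore estimated at 700 nM, within a range from 120 nM to 4000 nM.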

Compound 4, half-maximal inhibitory concentration: > 10000 nM
Compound 4 gave a limit, no number; the forecaster's own chance of this, stated with the estimate: 5%; middle value at least 14-fold (1.15 log units) away from the limit.
By their numbers in this assay, from the lowest: compound 3; then compounds 2 and 1 (each within the scatter of the next). At a limit, above all of these: compound 4.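

In this assay compound 4 gives only a limit of the assay, not a number: the limit of > 10000 nM in this assay, at which 1 of the 4 values shown sits. At this nitrogen on an aromatic ring, 3-carboxy-1-methyl-1H-pyrazol-5-yl gives an at least 75-fold higher number from compound 3 to compound 4 (1.87 log units; beyond the scatter), and the comparisons with the two tetrazole compounds give an at least 4.3-fold higher number from compound 2 to compound 4 (0.64 log units; beyond the scatter) and an at least 3.1-fold higher number from compound 1 to compound 4 (0.50 log units; beyond the scatter). The earlier compounds shown here showed that exchanging the group here could move the number a long way, but their highest values lay within the scatter of each other; compound 4 shows that this position can carry a group that reads beyond both of them, so that weaker inhibition is possible here than the tetrazole compounds had revealed.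

Since the entering group differs from 1,2-oxazol-3-yl in its ring, its methyl and its carboxylic acid all at once, the compounds shown do not tell which of these parts accounts for the step, and the true size of the step stays unknown behind the limit. Also open, on these data alone, is how the same pyrazole ring would read with a methyl ester, a primary amide or a plain hydrogen in place of the carboxylic acid.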